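From methoxy to hydroxy: one small change

This account rests on a few compounds, and the source may have more. Where it says the series, first, only, none or still open, it means among the compounds named here.

In an ADME assay on L6 cells (Rattus norvegicus) for cytotoxicity (on this read-out higher numbers stand for weaker inhibition and lower numbers for stronger inhibition), two related compounds have been tested so far. Going by the values given here, compound 2 `COc1cc(C2=NCCN2)ccc1-c1cc2cc(C3=NCCN3)ccc2o1` gives 7400 nM as the only true number available, which makes it the single firm reference point. Compound 1 `Oc1cc(C2=NCCN2)ccc1-c1cc2cc(C3=NCCN3)cc(O)c2o1` stands at > 193000 nM and this is a limit of the assay, not a number.

The step to compound 3 `Oc1cc(C2=NCCN2)ccc1-c1cc2cc(C3=NCCN3)ccc2o1` is small: hydrogen in place of methyl on an oxygen on an aromatic ring with hydrogen in place of methyl on an oxygen on an aromatic ring, which reads as methoxy to hydroxy. Among the compounds with values here, no measured pair shows this change on its own, so the expectation is loose. Compound 1 also bears a hydroxy, and its limit of > 193000 nM leans the expectation towards weaker inhibition. The expected change is moderate, with a 2.7-fold higher number from compound 2 to compound 3 (0.43 log units; beyond the scatter) as the estimated step towards weaker inhibition. Compound 3 is estimated at 20000 nM with 5000 nM to 90000 nM as the expected range.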

Compound 3, half-maximal inhibitory concentration: 150000 nM
Compound 3: the middle estimate sits 7.5-fold (0.88 log units) below what was measured; the whole stated range lies below it.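

Going by these compounds alone, exchanging methyl for hydrogen on the oxygen on the aromatic ring is, on its own, a large change in this assay, with a 20-fold higher number from compound 2 to compound 3 (1.31 log units; beyond the scatter); the earlier compounds could only hint at this, as compound 1 differs from compound 2 in more than one place. Exchanging the extra hydroxy on the aromatic carbon for hydrogen gives an at least 1.2-fold lower number from compound 1 to compound 3 (0.10 log units; that floor lies within the scatter), so this second change cannot be shown to matter. The value of compound 1 is a limit of the assay, not a number: the limit of > 193000 nM in this assay, at which 1 of the 3 values shown sits.

The compounds shown carry only methoxy and hydroxy on this oxygen-bearing position. On these data alone, how an ethoxy group, a longer chain on the oxygen or an amine in place of the hydroxy would read stays open, as does any true effect of the extra hydroxy in compound 1.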